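Swapping a Pyridine for a Pyrimidine on the Shared Core

A few compounds are considered here, and "the series" means these few. Any claim that something is new, unique, unknown or untested is made for them only; others in the source may bear on it.

Compound 1 `c1cncc(-c2ccccc2OCC2=NCCN2)c1`: 79.4 nM
Compound 2 `Cc1cccc(-c2ccccc2OCC2=NCCN2)n1`: < 100000 nM

For the measured compounds named here, in a functional assay for activation of Alpha-1B adrenergic receptor (Homo sapiens), read by calcium flux (a lower number here means that less compound is needed, a higher number that more compound is needed for the effect), compound 1 gives 79.4 nM, the only true number among the two values shown. For compound 2 the assay reports only a limit, < 100000 nM, which is not a number (the limit of < 100000 nM in this assay, at which 1 of the 2 values shown sits). Compound 3 `c1cnc(-c2ccccc2OCC2=NCCN2)nc1` is still to be measured in this assay; it differs from compound 1 by pyrimidin-2-yl in place of pyridin-3-yl on an aromatic carbon. Going by the values given here, no measured pair isolates this change, so its size is uncertain. The step from compound 1 to compound 3 is expected to be a 10-fold higher number from compound 1 to compound 3 (1.00 log units; beyond the scatter), toward needing more compound, beyond the usual scatter. Compound 3 is estimated at 800 nM, within 100 nM to 20000 nM.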

Compound 3, half-maximal effective concentration: < 100000 nM
Compound 3: a limit, no number; the forecaster's own chance of this, stated with the estimate: 30%; the middle value lies beyond the limit too.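

For the compounds shown here, compound 3 gives < 100000 nM and this is a limit, not a number, so no step from compound 1 to compound 3 can be read. The compounds shown leave open how large the effect of pyrimidin-2-yl in place of pyridin-3-yl is.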